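Primary amine chain length in the spiro series

This account rests on a few compounds, and the source may have more. Where it says the series, first, only, none or still open, it means among the compounds named here.

Compound 3 `COC(=O)CCCNC(=O)CN1CN(c2ccccc2)C2(CCN(C(=O)c3ccc(C(C)(C)C)cc3)CC2)C1=O` carries a methyl ester at the end of its side chain, and in an assay on HEK293 cells for displacement of a labelled ligand from NPC1-like intracellular cholesterol transporter 1 (Homo sapiens) (on this read-out higher numbers stand for weaker inhibition and lower numbers for stronger inhibition), compound 3 has "not determined" (no result reported), so no single number places it against the others. Among the measured compounds shown here, the two measured members are compound 1 `CC(C)(C)c1ccc(C(=O)N2CCC3(CC2)C(=O)N(CC(=O)N2CCNCC2)CN3c2ccccc2)cc1`, which in this assay gives 22000 nM, and compound 2 `CC(C)(C)c1ccc(C(=O)N2CCC3(CC2)C(=O)N(CC(=O)NCCCN)CN3c2ccccc2)cc1`, which in this assay gives 4200 nM. For the measured compounds named here, the only measured step, a 5.2-fold lower number from compound 1 to compound 2 (0.72 log units; beyond the scatter), shows that a terminal primary amine on a chain is tolerated and reads as a modest gain.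

The change to compound 4 `CC(C)(C)c1ccc(C(=O)N2CCC3(CC2)C(=O)N(CC(=O)NCCCCN)CN3c2ccccc2)cc1` is aminomethyl in place of methoxycarbonyl on a saturated chain carbon, three bonds along the chain from an amide-type nitrogen. Going by the values given here, no measured step covers an ester to amine exchange directly, so compound 3 offers no anchor. Compound 4 is closest to compound 2, differing only by chain length, and the step from compound 1 to compound 2 suggests a terminal amine in this region sits in the low-micromolar range. Compound 4 is therefore expected to fall near compound 2, estimated at 4500 nM with a range of 1500 nM to 14000 nM, with no confident direction relative to compound 2.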

Compound 4, half-maximal inhibitory concentration: 14500 nM
The estimate for compound 4 lay 3.2-fold (0.51 log units) below the measured number; measured number outside the range, above it.
By their numbers in this assay, from the lowest: compound 2; then compounds 4 and 1 (each within the scatter of the next).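

Chain length at the terminal primary amine matters in this assay: lengthening 3-aminopropyl to 4-aminobutyl gives a 3.5-fold higher number from compound 2 to compound 4 (0.54 log units; beyond the scatter), so the position is sensitive to this small change. The gain seen for compound 2 therefore does not extend to every terminal primary amine on this chain, since a 1.5-fold lower number from compound 1 to compound 4 (0.18 log units; within the scatter) puts compound 4 no clear distance from the piperazin-1-yl amide of compound 1. Nothing measured here bears on the reason for this sensitivity.

On these data alone, whether a shorter 2-aminoethyl chain or a longer 5-aminopentyl chain continues this trend remains open. Also open, as far as these compounds go, is how a carboxylic acid or the methoxycarbonyl end of compound 3 compares with a terminal amine at this position.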